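From methoxy to nitro: what compound 4 may show

A few compounds are considered here, and "the series" means these few. Any claim that something is new, unique, unknown or untested is made for them only; others in the source may bear on it.

Measured in an ADME assay on HEK-293T cells (Homo sapiens) for inhibition, read by CCK-8 assay, with a stated time of 48 h, tested at 20 uM; on this read-out lower numbers stand for less inhibition of growth and higher numbers for more inhibition of growth at the one concentration tested:
- compound 1 `COc1ccc(Cc2nnc(NC(=O)/C(C#N)=C/c3ccccc3OS(=O)(=O)c3ccc([N+](=O)[O-])cc3)s2)cc1`: 17%
- compound 2 `Cc1ccc(S(=O)(=O)Oc2ccccc2/C=C(\C#N)C(=O)Nc2nnc(Cc3ccc(F)cc3)s2)cc1`: 16%
- compound 3 `COc1ccc(S(=O)(=O)Oc2ccccc2/C=C(\C#N)C(=O)Nc2nnc(Cc3ccc(F)cc3)s2)cc1`: 20%

In this assay, compound 3 gives 20%. That value lies within the scatter of the other two, so the three compounds cannot be ranked. The next compound, compound 4 `N#C/C(=C\c1ccccc1OS(=O)(=O)c1ccc([N+](=O)[O-])cc1)C(=O)Nc1nnc(Cc2ccc(F)cc2)s1`, keeps the structure of compound 3 except for one change: nitro in place of methoxy on an aromatic carbon, para to a large group (nitro in place of methoxy on an aromatic carbon).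

Going by the values given here, one measured step bears directly on this spot. Methoxy in place of methyl on an aromatic carbon gives a number 4 percentage points higher from compound 2 to compound 3 (within the scatter). Among the compounds with values here, compound 1 is the only measured compound that carries a nitro group, and compound 1 gives 17%. Within the data shown here, no measured pair isolates the nitro group, so this is only indirect support. Among the measured compounds shown here, nothing measured so far points to a large move in this assay, and none beyond the scatter is expected. The expected change is a number 1 percentage points lower from compound 3 to compound 4 (within the scatter). Compound 4 is estimated at 19%, with an expected range from 10% to 30%.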

Compound 4, percent growth inhibition at one concentration: 8%
The estimate for compound 4 lay 11 percentage points above the measured number; the whole stated range lies above it.
By their numbers in this assay, from the lowest: compounds 4, 2, 1 and 3 (each within the scatter of the next, the first and the last beyond it).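

In this assay, going by these compounds alone, the group on this aromatic ring can matter: nitro in place of methoxy gives a number 12 percentage points lower from compound 3 to compound 4 (beyond the scatter) and is the first step in this set to pass the usual scatter. That step is modest, and the other two remain within the scatter: nitro in place of methyl gives a number 8 percentage points lower from compound 2 to compound 4 (within the scatter) while the change to fluoro gives a number 9 percentage points lower from compound 1 to compound 4 (within the scatter) and neither can be read as a real change. Nothing available explains why the nitro and methoxy pair separates in this way.

On these data alone, it remains open whether an amine or a carboxylic acid at this spot would give numbers closer to those of compound 3 or compound 4. A single pair also cannot show whether the same swap would give a similar step on a different core.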